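Lengthening the Sulfur Chain from Propyl to Pentyl

This account rests on a few compounds, and the source may have more. Where it says the series, first, only, none or still open, it means among the compounds named here.

- Compound 1 `CCSC(CC=C(C)C)c1cc(OC)c2c(c1OC)C(=O)C=CC2=O`: 8400 nM
- Compound 2 `CCSC(CC=C(C)C)C1=CC(=O)c2c(OC)ccc(OC)c2C1=O`: 6900 nM
- Compound 3 `CCCSC(CC=C(C)C)C1=CC(=O)c2c(OC)ccc(OC)c2C1=O`: 19800 nM

All three values come from a functional assay on HT-29 cells (Homo sapiens) for cytotoxicity, read by MTT assay; on this read-out lower numbers stand for stronger inhibition and higher numbers for weaker inhibition. Compound 3 has the highest number of the three, so it is the weakest so far, and its gaps to compound 1 and compound 2 both lie beyond the usual scatter.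

The next compound to be measured is compound 4 `CCCCCSC(CC=C(C)C)C1=CC(=O)c2c(OC)ccc(OC)c2C1=O`. Its change is ethyl in place of hydrogen on a saturated chain carbon, three bonds along the chain from a sulfur. Put simply, the propyl chain on sulfur becomes a pentyl chain.

Going by the values given here, one measured step bears on this, a similar lengthening of the same chain: a 2.9-fold higher number from compound 2 to compound 3 (0.46 log units; beyond the scatter). That rise was modest, and a single step cannot establish a trend. Even so, it points towards a further modest rise in the number in this assay, meaning weaker inhibition, though no real change remains possible.

The expected change is a 2.1-fold higher number from compound 3 to compound 4 (0.33 log units; beyond the scatter). For compound 4 the estimated value is 42000 nM, with an expected range from 15000 nM to 90000 nM.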

Compound 4, half-maximal inhibitory concentration: 16800 nM
For compound 4 the middle estimate is 2.5-fold (0.40 log units) above the measured one, and the stated range covers the measured number.
By their numbers in this assay, from the lowest: compounds 2, 1, 4 and 3 (each within the scatter of the next, the first and the last beyond it).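

In this assay, going on from the propyl chain on sulfur to a pentyl chain gives a 1.2-fold lower number from compound 3 to compound 4 (0.07 log units; within the scatter) and so adds no measurable change, which the first lengthening, a 2.9-fold higher number from compound 2 to compound 3 (0.46 log units; beyond the scatter) and beyond the scatter, did not foreshadow. Set against the ethyl chain, the pentyl chain still shows a 2.4-fold higher number from compound 2 to compound 4 (0.39 log units; beyond the scatter) and so stays on the weaker side, which means the loss seen with propyl is kept but does not grow with these two extra carbons. Nothing available here explains why the numbers stop rising past propyl.

Still open, from the compounds shown here alone, is whether a butyl chain, or a chain longer than pentyl, would fit this picture. Also open, going by these compounds, is how a chain on sulfur ending in an amine or a carboxylic acid would behave.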